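Clearance after a 1,3-benzoxazol-5-yl swap

The compounds below may be only part of what the source reports. "The series", "measured", "known", "first", "only" and "open" are said of these compounds alone.

Compound 1 `Nc1ccc(S(=O)(=O)N2CCN(c3ncc(C(O)(C(F)(F)F)C(F)(F)F)cc3-c3cnccc3F)CC2)cn1`: 22 mL.min-1.g-1
Compound 2 `COc1cncc(-c2cc(C(O)(C(F)(F)F)C(F)(F)F)cnc2N2CCN(S(=O)(=O)c3ccc(N)nc3)CC2)c1`: 58 mL.min-1.g-1

In an ADME assay (liver) for metabolic stability, with Liver microsome (Rattus norvegicus) as the target, using microsomes and NADPH, with a stated time of 30 min, tested at 1 uM (on this read-out higher numbers stand for fast clearance and lower numbers for slow clearance), compound 2 gives 58 mL.min-1.g-1, the higher of the two numbers, so it is the faster cleared of the pair. Compound 3 `Nc1ccc(S(=O)(=O)N2CCN(c3ncc(C(O)(C(F)(F)F)C(F)(F)F)cc3-c3ccc4ocnc4c3)CC2)cn1` differs from it in one place: 1,3-benzoxazol-5-yl in place of 5-methoxypyridin-3-yl on an aromatic carbon. For the measured compounds named here, only one measured step touches that same place: a 2.6-fold higher number from compound 1 to compound 2 (0.42 log units; beyond the scatter). Going by the values given here, that modest step shows that a swap here can move the number, but it involved 4-fluoropyridin-3-yl and 5-methoxypyridin-3-yl, and no measured compound carries 1,3-benzoxazol-5-yl. The data therefore give no direction. A move of similar size either way remains possible, but the central expectation in this assay is no change beyond the scatter. The expected step is a 1.2-fold lower number from compound 2 to compound 3 (0.06 log units; within the scatter). For compound 3 the estimated value is 50 mL.min-1.g-1, with an expected range from 20 mL.min-1.g-1 to 120 mL.min-1.g-1.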

Compound 3, intrinsic clearance in microsomes: 120 mL.min-1.g-1
Estimate against measurement, compound 3: 2.4-fold (0.38 log units) below, and the stated range covers the measured number.
By their numbers in this assay, from the lowest: compound 1; then compound 2; then compound 3.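

In this assay, this position, on an aromatic carbon ortho to a large group, responds not only to a swap between two pyridine groups but also to a group built from a five-membered and a six-membered aromatic ring: 1,3-benzoxazol-5-yl in place of 5-methoxypyridin-3-yl gives a 2.1-fold higher number from compound 2 to compound 3 (0.32 log units; beyond the scatter). Against 4-fluoropyridin-3-yl, the same group gives a 5.5-fold higher number from compound 1 to compound 3 (0.74 log units; beyond the scatter), the largest of the three steps at this position, which places compound 3 as the fastest cleared of the set. No measurement here explains why clearance differs between these groups.

On these data alone, how an open-chain amine or a carboxylic acid at this position would compare remains open. So does whether the order of these three groups would hold on a different core.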